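This account rests on a few compounds, and the source may have more. Where it says the series, first, only, none or still open, it means among the compounds named here.

Measured compounds in a functional assay on CHO-K1 cells for antagonist activity at adenosine receptor A1 (Homo sapiens), read by a beta-galactosidase reporter and cAMP accumulation, with stated times of 15 min and 6 h; a lower number here means a stronger inhibitor, a higher number a weaker inhibitor:
compound 1 `Cc1ccc(-c2nc(N)c3ccsc3n2)o1` gives 493 nM
compound 2 `Cc1ccc(-c2nc(N)c3cc(Cc4ccccc4Cl)sc3n2)o1` gives 26.1 nM
compound 3 `Nc1nc(-c2ccc(C3CC3)o2)nc2sc(Cc3ccccc3)cc12` gives 861 nM

Compound 3 has the highest number of the three. Its nearest neighbour is compound 1, whose value lies within the scatter of that of compound 3, so no order between them is claimed. Going by the values given here, compound 2 sits far lower, and the one step in the set, a 19-fold lower number from compound 1 to compound 2 (1.28 log units; beyond the scatter), shows what the 2-chlorobenzyl group brings.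

Compound 4 `Nc1nc(-c2ccccc2)nc2sc(Cc3ccccc3)cc12` is the next compound. It differs from compound 3 as follows: phenyl in place of 5-cyclopropylfuran-2-yl on an aromatic carbon. Among the compounds with values here, the only measured step concerns a different site and a different kind of change; it does not bear on the exchange of the furan-bearing group for phenyl, and no pair among the measured compounds shows that exchange. The expectation therefore rests on compound 3 alone, with wide uncertainty.

An estimated step of a 1.5-fold higher number from compound 3 to compound 4 (0.18 log units; within the scatter) in this assay is expected, a modest rise that may lie within the scatter. For compound 4 the estimated value is 1300 nM, with a range from 400 nM to 4500 nM.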

Compound 4, inhibition constant: 151 nM
Estimate against measurement, compound 4: 8.6-fold (0.93 log units) above; the measured number lies below the stated range.
By their numbers in this assay, from the lowest: compound 2; then compound 4; then compounds 1 and 3 (each within the scatter of the next).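

In this assay, the group on the aromatic carbon between two ring nitrogen atoms proves to matter as well: phenyl in place of 5-cyclopropylfuran-2-yl gives a 5.7-fold lower number from compound 3 to compound 4 (0.76 log units; beyond the scatter) as a step beyond the scatter. Going by these compounds alone, this is the first reading at this position, as the earlier step concerned only the site of the 2-chlorobenzyl group, and it shows that a furan ring is not needed here for a lower number. No available evidence accounts for this step.

The compounds shown do not separate the contribution of the furan ring from that of its cyclopropyl group, and they do not show whether the step holds when 2-chlorobenzyl is present on the core. On these data alone, how a phenyl bearing a methoxy group or a primary amine would read at this position also remains open.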